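The compounds below may be only part of what the source reports. "The series", "measured", "known", "first", "only" and "open" are said of these compounds alone.

Measured in a functional assay on K562 cells (Homo sapiens) for cytotoxicity, read by ELISA, with a stated time of 4 days; a higher number here means a weaker inhibitor, a lower number a stronger inhibitor:
compound 1 `Cc1ccsc1-c1cc(-c2ccco2)cc(-c2ccccc2Cl)n1`: 25400 nM
compound 2 `Cc1ccsc1-c1cc(-c2ccoc2)cc(-c2ccco2)n1`: 23300 nM
compound 3 `Clc1ccc(-c2cc(-c3ccoc3)cc(-c3ccco3)n2)s1`: 16200 nM

In this assay, compound 3 gives 16200 nM, and this number lies within the usual scatter of both others. The three compounds therefore cannot be ranked on these data.

The next compound to be tested is compound 4 `Clc1ccc(-c2cc(-c3ccoc3)cc(-c3ccccn3)n2)s1`, which has pyridin-2-yl in place of furan-2-yl on an aromatic carbon. Among the measured compounds shown here, no measured step replaces furan-2-yl, so the data offer no direct guide to this change. For the measured compounds named here, the only measured step between two close relatives is a 1.4-fold lower number from compound 2 to compound 3 (0.16 log units; within the scatter). It exchanges a different group, so it bears on this change only loosely, showing that one substitution on this core left the number within the scatter. With nothing pointing in either direction, no change beyond the scatter is expected, and the expected step is a 1.2-fold lower number from compound 3 to compound 4 (0.10 log units; within the scatter). For compound 4 the estimated value is 13000 nM, with an expected range from 5000 nM to 32000 nM.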

Compound 4, half-maximal inhibitory concentration: 20000 nM
Compound 4: middle estimate off by 1.5-fold (0.19 log units), on the low side; the measured number falls inside the stated range.
By their numbers in this assay, from the lowest: compounds 3, 4, 2 and 1 (each within the scatter of the next).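

On the carbon next to the ring nitrogen, the shared core accepts a six-membered aromatic ring in place of a five-membered one without a readable shift: in this assay, pyridin-2-yl in place of furan-2-yl gives a 1.2-fold higher number from compound 3 to compound 4 (0.09 log units; within the scatter) and stays within the scatter. Among the compounds shown here, the earlier step concerned the thiophene group, so this is the first sign that this second position also tolerates an exchange, at least between these two rings, each with one hetero atom and one hydrogen-bond acceptor. No independent measurement bears on this result.

On these data alone, whether a different kind of group here, such as an amine or a carboxylic acid, would move the number beyond the scatter remains open. As far as these compounds go, it is also open whether this exchange would behave the same way with the 3-methylthiophen-2-yl group of compound 2 in place of the 5-chlorothiophen-2-yl group.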